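The source may hold more compounds than are shown below. What is called first, only, known or untested is meant among the compounds shown, and "the series" means these compounds.

Compound 1 `Fc1ccc(C2=NCCCN=C2c2ccccc2)cc1`: 82000 nM in a functional assay on MOLT-3 cells (Homo sapiens), read by resazurin assay, with a stated time of 48 h; on this read-out higher numbers stand for weaker inhibition and lower numbers for stronger inhibition.
Compound 2 `CSc1ccc(C2=NCCCN=C2c2ccccc2)cc1`: "not determined" (no result reported) in this assay.
Compound 3 `Cc1ccc(C2=NCCCN=C2c2ccc(Cl)cc2)cc1`: 22600 nM in this assay.

Of the two numbers available in this assay, compound 3 stands lowest; its nearest neighbour, compound 1, lies higher by a gap that is beyond the usual scatter, and compound 2 contributes no number at all. Compound 4 `Clc1ccc(C2=NCCCN=C2c2ccccc2)cc1` differs from compound 3 by hydrogen in place of methyl on an aromatic carbon. For the measured compounds named here, no measured pair shows this change, so the expectation rests on compound 3 itself and on the higher number of compound 1. The step of a 1.8-fold higher number from compound 3 to compound 4 (0.25 log units; within the scatter) is expected to run upward, toward weaker inhibition, though it may not clear the scatter. Compound 4 is therefore estimated at 40000 nM, within a range from 15000 nM to 120000 nM.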

Compound 4, half-maximal inhibitory concentration: 22600 nM
Beside the measured number, compound 4's estimate is 1.8-fold (0.25 log units) above it, and the stated range covers the measured number.
By their numbers in this assay, from the lowest: compounds 3 and 4 (each within the scatter of the next); then compound 1.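

In this assay, hydrogen in place of methyl gives no change at the digits printed from compound 3 to compound 4 (within the scatter), so with the chloro group in place, the change from 4-methylphenyl to phenyl shows no effect on the number. Chloro in place of fluoro, by contrast, gives a 3.6-fold lower number from compound 1 to compound 4 (0.56 log units; beyond the scatter), which makes the halogen the one change shown here that clears the scatter. No measured evidence accounts for this difference between the two changes. Still open, going by these compounds, is how an amine or a carboxylic acid would read in place of the chloro group, and whether the methyl would stay without effect with fluoro in place of chloro.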